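The source may report more compounds than this note shows. Statements on the series, on what has been measured and on what is new or still open speak of the compounds shown alone.

Compound 3 `Clc1ccc(-c2cc(-c3ccc(Cl)o3)cc(-c3ccsc3)n2)cc1` carries a 5-chlorofuran-2-yl group, a thiophen-3-yl group and a 4-chlorophenyl group on its shared core. In a functional assay on DU-145 cells (Homo sapiens) for cytotoxicity, in the presence of a further agent that is not named here (on this read-out higher numbers stand for weaker inhibition and lower numbers for stronger inhibition), compound 3 gives 19500 nM. Two measured neighbours frame it. Compound 1 `Clc1ccc(-c2cc(-c3ccc(Cl)o3)cc(-c3cccs3)n2)cc1` gives 19200 nM, and the step of a 1.0-fold higher number from compound 1 to compound 3 (0.01 log units; within the scatter) is a swap of thiophen-3-yl for thiophen-2-yl. Compound 2 `Clc1ccc(-c2cc(-c3ccsc3)nc(-c3ccccn3)c2)o1` gives 10900 nM, and the step of a 1.8-fold higher number from compound 2 to compound 3 (0.25 log units; within the scatter) exchanges pyridin-2-yl for 4-chlorophenyl at the same position that is now in question. Compound 3 thus sits among three numbers that all lie within the scatter of one another, so no order among them can be read.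

Compound 4 `Clc1ccc(-c2cc(-c3ccsc3)nc(-c3ccco3)c2)o1` differs from compound 3 in one place: furan-2-yl in place of 4-chlorophenyl on an aromatic carbon. Within the data shown here, the only measured step that touches this position, a 1.8-fold higher number from compound 2 to compound 3 (0.25 log units; within the scatter), was within the scatter, and an earlier exchange of one aromatic ring for another elsewhere on the core, a 1.0-fold higher number from compound 1 to compound 3 (0.01 log units; within the scatter), was likewise flat. On that basis no step beyond the scatter is expected in this assay for compound 4, and the change a 1.3-fold lower number from compound 3 to compound 4 (0.11 log units; within the scatter) is taken as an estimate of essentially no movement. Compound 4 is therefore expected to give about 15000 nM, within a range from 6000 nM to 40000 nM.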

Compound 4, half-maximal inhibitory concentration: 18900 nM
The estimate for compound 4 lay 1.3-fold (0.10 log units) below the measured number; measured number inside the range.
By their numbers in this assay, from the lowest: compounds 2, 4, 1 and 3 (each within the scatter of the next).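

The position next to the ring nitrogen now carries three different aromatic rings with the 5-chlorofuran-2-yl and thiophen-3-yl groups unchanged: 4-chlorophenyl in compound 3, pyridin-2-yl in compound 2 and furan-2-yl in compound 4. In this assay the exchange of a six-membered carbon ring for a smaller five-membered ring with a hetero atom and a hydrogen-bond acceptor, and the loss of chlorine with it, leaves the number flat (a 1.0-fold lower number from compound 3 to compound 4 (0.01 log units; within the scatter)), and replacing pyridin-2-yl with furan-2-yl also stays inside the noise (a 1.7-fold higher number from compound 2 to compound 4 (0.24 log units; within the scatter)). No difference among these three rings can therefore be read at this position, which a single step there could not establish.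

Every group shown at this position is an aromatic ring, so it remains open whether an amine, a carboxylic acid or a longer alkyl chain there would move the number beyond the scatter. Why these rings cannot be told apart also remains open, as no measurement at hand bears on it.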